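Swapping tert-butyl for (trifluoromethyl)sulfanyl: what happens to solubility?

This account rests on a few compounds, and the source may have more. Where it says the series, first, only, none or still open, it means among the compounds named here.

Compound 1 `Cc1cc(NC(=O)Nc2ccc(C(C)(C)C)cc2)c2ccccc2n1` has the highest solubility of the three measured compounds: in a physicochemical assay for solubility, at pH 7.4 (a higher number here means a more soluble compound, a lower number a less soluble compound), compound 1 gives 6200 nM. Compound 3 `COC(=O)c1cccc(NC(=O)Nc2cc(C)nc3ccccc23)c1` comes nearest, and in this assay compound 3 gives 600 nM, a gap beyond the scatter. Compound 2 `Cc1cc(NC(=O)Nc2ccc(Cl)c(Cl)c2)c2ccccc2n1` stands furthest away; in this assay compound 2 gives 300 nM. Compound 4 `Cc1cc(NC(=O)Nc2ccc(SC(F)(F)F)cc2)c2ccccc2n1` has not yet been measured. It differs from compound 1 in a single place: (trifluoromethyl)sulfanyl in place of tert-butyl on an aromatic carbon. Within the data shown here, no pair of measured compounds isolates this change, so no measured step can simply be carried over. The change is expected to bring a modest fall, on the order of a 2.5-fold lower number from compound 1 to compound 4 (0.39 log units; beyond the scatter) in this assay. Compound 4 is therefore estimated at 2500 nM in this assay, within a range from 600 nM to 8000 nM.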

Compound 4, solubility: 200 nM
Estimate against measurement, compound 4: 13-fold (1.10 log units) above; the whole stated range lies above it.
By their numbers in this assay, from the lowest: compounds 4, 2 and 3 (each within the scatter of the next, the first and the last beyond it); then compound 1.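

In this assay, among these compounds, (trifluoromethyl)sulfanyl in place of tert-butyl on an aromatic carbon gives a 31-fold lower number from compound 1 to compound 4 (1.49 log units; beyond the scatter) and this large drop is the only measured step at this position. It shows that the high number of compound 1 does not survive a single change of this group on the shared core. Nothing at hand accounts for the size of this step.

As far as these compounds go, whether an amine, a carboxylic acid or a longer chain at this position would stay nearer to compound 1 remains open. So does whether this change would bring a step of similar size on another core.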